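The source may report more compounds than this note shows. Statements on the series, on what has been measured and on what is new or still open speak of the compounds shown alone.

Compound 1 `O=C(NNc1ccccc1F)c1ccc(NS(=O)(=O)c2cnc(O)nc2O)cc1`: > 20000 nM
Compound 2 `Cc1ccccc1NNC(=O)c1cccc(NS(=O)(=O)c2cnc(O)nc2O)c1`: > 20000 nM

Both entries are limits, not numbers. In a functional assay on OVCAR-3 cells (Homo sapiens) for antiproliferative activity, read by MTT assay, with a stated time of 24 h (a lower number here means a stronger inhibitor, a higher number a weaker inhibitor), compound 2 stands at > 20000 nM, which is a limit. Among the measured compounds shown here, compound 1, the only other compound measured, gives > 20000 nM, also a limit. The whole picture so far is the limit of > 20000 nM in this assay, at which 2 of the 2 values shown sit.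

Compound 3 `O=C(NNc1ccc(F)cc1)c1cccc(NS(=O)(=O)c2cnc(O)nc2O)c1` differs from compound 2 in a single group: 4-fluorophenyl in place of 2-methylphenyl on an amine nitrogen. Here 4-fluorophenyl takes the place of 2-methylphenyl on an amine nitrogen. For the measured compounds named here, no measured pair shows what such a swap does. No change beyond the usual scatter is expected in this assay, and another limit is the likeliest result. This expectation rests on compound 2, with its limit of > 20000 nM. The expected move is a step that the limit leaves unreadable from compound 2 to compound 3. For compound 3 the estimated value is 30000 nM, with an expected range from 12000 nM to 70000 nM.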

Compound 3, half-maximal inhibitory concentration: > 20000 nM
Compound 3: no number, only a limit; the forecaster's own chance of this, stated with the estimate: 80%; the middle value lies beyond the limit too.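

Compound 2 and compound 3 each give only a limit in this assay, so the step between them cannot be read. The compounds shown leave open how they rank against one another, and whether any change to the shared core gives a measurable value.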